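A few compounds are considered here, and "the series" means these few. Any claim that something is new, unique, unknown or untested is made for them only; others in the source may bear on it.

In a functional assay on G-361 cells (Homo sapiens) for cytotoxicity, read by MTT assay, with a stated time of 3 days (a higher number here means a weaker inhibitor, a lower number a stronger inhibitor), three compounds built on one shared core have been measured, differing only in a single group on an aromatic carbon. Compound 1 `N#Cc1c(O)nc(SCc2nc3ccccc3[nH]2)nc1-c1ccccc1` gives 3.43 nM, compound 2 `N#Cc1c(Cl)nc(SCc2nc3ccccc3[nH]2)nc1-c1ccccc1` gives 12.5 nM, and compound 3 `N#Cc1c(NN)nc(SCc2nc3ccccc3[nH]2)nc1-c1ccccc1` gives 14.7 nM. Compound 3 therefore stands level with compound 2, within the scatter, and both have higher numbers than compound 1.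

Compound 4 `N#Cc1c(Nc2ccccc2)nc(SCc2nc3ccccc3[nH]2)nc1-c1ccccc1` differs from compound 3 by one change: phenyl in place of amino on a nitrogen on an aromatic ring. Seen one bond further out, the aminoamino group of compound 3 becomes the anilino group of compound 4.

Among the measured compounds shown here, no measured step makes this exact change, so the nearest guides are the other swaps of this group: a 3.6-fold higher number from compound 1 to compound 2 (0.56 log units; beyond the scatter), a 4.3-fold higher number from compound 1 to compound 3 (0.63 log units; beyond the scatter) and a 1.2-fold higher number from compound 2 to compound 3 (0.07 log units; within the scatter). The two steps away from hydroxy are modest, and the step between the two non-hydroxy groups stays within the scatter. Anilino has not been tested here, so a step beyond the scatter in this assay is not expected in either direction, though the uncertainty is wide. The expected change is a 1.1-fold lower number from compound 3 to compound 4 (0.02 log units; within the scatter). For compound 4 the estimated value is 14 nM, with an expected range from 5 nM to 45 nM.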

Compound 4, half-maximal inhibitory concentration: 2.4 nM
Beside the measured number, compound 4's estimate is 5.8-fold (0.77 log units) above it; the whole stated range lies above it.
By their numbers in this assay, from the lowest: compounds 4 and 1 (each within the scatter of the next); then compounds 2 and 3 (each within the scatter of the next).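

In this assay, among the compounds shown here, the earlier compounds carried only small groups on this aromatic carbon, and compound 4 shows that a phenyl ring can be carried there through the nitrogen. Phenyl in place of amino on that nitrogen gives a 6.1-fold lower number from compound 3 to compound 4 (0.79 log units; beyond the scatter) and anilino in place of chloro gives a 5.2-fold lower number from compound 2 to compound 4 (0.72 log units; beyond the scatter), while anilino in place of hydroxy gives a 1.4-fold lower number from compound 1 to compound 4 (0.16 log units; within the scatter), so two quite different groups, hydroxy and anilino, sit level here. No measurement shown here explains why these groups differ in this way.

The compounds shown leave open whether the aromatic ring itself matters, or whether a methyl or cyclohexyl group on the same nitrogen would do as well. As far as these compounds go, how a phenyl ring bearing a methoxy group or a fluorine would behave also remains open.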